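Replacing the oxane ring with a hydroxylated dimethylcyclohexyl group

The source may hold more compounds than are shown below. What is called first, only, known or untested is meant among the compounds shown, and "the series" means these compounds.

Three compounds share a core and differ only in the group carried on a nitrogen on the aromatic ring. Compound 1 `CO[C@H]1CC[C@H](Nc2cc(NCc3cnccc3C(F)(F)F)ncc2C#N)CC1` gives 1100 nM in an assay on isolated protein for inhibition of protein kinase C theta type (Homo sapiens), read by TR-FRET, with a stated time of 2 h; a higher number here means a weaker inhibitor, a lower number a stronger inhibitor. Compound 2 `N#Cc1cnc(NCc2cnccc2C(F)(F)F)cc1NC[C@H]1CC[C@@H](O)CC1` gives 58 nM in this assay, and compound 3 `N#Cc1cnc(NCc2cnccc2C(F)(F)F)cc1NC1CCOCC1` gives 900 nM. Compound 3 and compound 1 sit close together, within the usual scatter, whereas the gap to compound 2 is beyond it: a 16-fold higher number from compound 2 to compound 3 (1.19 log units; beyond the scatter).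

Compound 4 `CC1(C)C[C@H](Nc2cc(NCc3cnccc3C(F)(F)F)ncc2C#N)CC[C@@H]1O` has not yet been measured. The change from compound 3 is 4-hydroxy-3,3-dimethylcyclohexyl in place of oxan-4-yl on a nitrogen on an aromatic ring. The measured steps that bear on it are a 16-fold higher number from compound 2 to compound 3 (1.19 log units; beyond the scatter), where a hydroxycyclohexyl-bearing group gave the strongest inhibition seen here, and a 19-fold lower number from compound 1 to compound 2 (1.28 log units; beyond the scatter), where a free hydroxyl outdid a methoxy. Compound 4 carries its hydroxycyclohexyl directly rather than through a methylene and adds two methyl groups, so a substantial drop in number is expected, though probably not the full size seen in the step from compound 2 to compound 3. For compound 4 the expected step is an 8.2-fold lower number from compound 3 to compound 4 (0.91 log units; beyond the scatter). Compound 4 is therefore estimated at 110 nM, with a likely range from 30 nM to 400 nM.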

Compound 4, half-maximal inhibitory concentration: 7 nM
Compound 4: middle estimate off by 16-fold (1.20 log units), on the high side, outside the stated range (below it).
By their numbers in this assay, from the lowest: compound 4; then compound 2; then compounds 3 and 1 (each within the scatter of the next).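

The earlier compounds shown here left open whether a ring attached directly to this nitrogen could give strong inhibition, since the two such rings, in compound 1 and compound 3, both sat at the weak end. The 4-hydroxy-3,3-dimethylcyclohexyl group settles that in this assay: it brings a 130-fold lower number from compound 3 to compound 4 (2.11 log units; beyond the scatter) and a 160-fold lower number from compound 1 to compound 4 (2.20 log units; beyond the scatter) while sitting directly on the nitrogen. A methylene link is also not needed for the best result here, as the step of an 8.3-fold lower number from compound 2 to compound 4 (0.92 log units; beyond the scatter) goes further still.

The change brings in a hydroxyl and two methyl groups together, so the compounds shown cannot divide the gain between them. Going by these compounds, whether an amine or a carboxylic acid could stand in for the hydroxyl also remains open. No measurement offered here accounts for these steps.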